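The source may hold more compounds than are shown below. What is called first, only, known or untested is meant among the compounds shown, and "the series" means these compounds.

Three analogues of a shared core have been measured in a functional assay on T47D cells (Homo sapiens) for inhibition, read by sulforhodamine B assay, with a stated time of 48 h; a lower number here means a stronger inhibitor of growth, a higher number a weaker inhibitor of growth. Compound 1 `COC(=O)[C@@]1(C)CCC=C2[C@@H]1CC[C@@H](C)[C@]2(C)Cc1c(C)[nH]c2ccc(Br)cc12` gives 16000 nM, compound 2 `COC(=O)[C@@]1(C)CCC=C2[C@@H]1CC[C@@H](C)[C@]2(C)Cc1c(C)[nH]c2ccc(Cl)cc12` gives 17000 nM, and compound 3 `COC(=O)[C@@]1(C)CCC=C2[C@@H]1CC[C@@H](C)[C@]2(C)Cc1c(C)[nH]c2ccc(F)cc12` gives 15000 nM. Compound 3 holds the lowest of the three numbers, but every step separating it from the others lies within the scatter. Compound 4 `COC(=O)[C@@]1(C)CCC=C2[C@@H]1CC[C@@H](C)[C@]2(C)Cc1c(C)[nH]c2ccc(C(F)(F)F)cc12` differs from compound 3 by trifluoromethyl in place of fluoro on an aromatic carbon. The measured steps that bear on this each exchange one halogen for another on an aromatic carbon: a 1.1-fold higher number from compound 1 to compound 2 (0.03 log units; within the scatter), a 1.1-fold lower number from compound 1 to compound 3 (0.03 log units; within the scatter) and a 1.1-fold lower number from compound 2 to compound 3 (0.05 log units; within the scatter). Within the data shown here, none reached beyond the scatter, and no measured step introduces a trifluoromethyl. Compound 4 is therefore expected to show no step beyond the scatter in this assay, estimated at 15000 nM with a range from 6000 nM to 40000 nM. That estimate corresponds to no change at the digits printed from compound 3 to compound 4 (within the scatter).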

Compound 4, concentration for 50% growth inhibition: 21000 nM
Compound 4: the middle estimate sits 1.4-fold (0.15 log units) below what was measured; the measured number falls inside the stated range.
By their numbers in this assay, from the lowest: compounds 3, 1, 2 and 4 (each within the scatter of the next).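

In this assay the position takes trifluoromethyl, a group of four heavy atoms, with no step beyond the scatter against fluoro (a 1.4-fold higher number from compound 3 to compound 4 (0.15 log units; within the scatter)), against chloro (a 1.2-fold higher number from compound 2 to compound 4 (0.09 log units; within the scatter)) or against bromo (a 1.3-fold higher number from compound 1 to compound 4 (0.12 log units; within the scatter)). The exchange of one halogen for another had not shown this, since each of those groups has a single heavy atom. No measurement here accounts for this flat result. Going by these compounds, whether an amine, a carboxylic acid or a longer chain at this position would move the number beyond the scatter stays open.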